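Swapping a methylthiazole amide for a chlorophenyl amide

A few compounds are considered here, and "the series" means these few. Any claim that something is new, unique, unknown or untested is made for them only; others in the source may bear on it.

Three amides on a shared core have been tested in a functional assay on MDA-MB-468 cells (Homo sapiens) for antiproliferative activity, read by MTT assay, with a stated time of 72 h; on this read-out higher numbers stand for weaker inhibition and lower numbers for stronger inhibition. Compound 1 `O=C(Nc1ccc(Cl)c(-c2nnc3c(Cl)cccn23)c1)c1ccc(C(F)(F)F)cc1F` gives 22300 nM. Compound 3 `O=C(Nc1ccc(Cl)c(-c2nnc3c(Cl)cccn23)c1)c1cccc(Cl)c1` gives 54800 nM. Compound 2 `Cc1nc(C(=O)Nc2ccc(Cl)c(-c3nnc4c(Cl)cccn34)c2)cs1` reaches only the limit of this assay, > 100000 nM, so on the numbers shown its position is a ceiling rather than a value (the limit of > 100000 nM in this assay, at which 1 of the 3 values shown sits). Among the compounds with values here, the one measured step between these compounds that differ in a single place is an at least 1.8-fold lower number from compound 2 to compound 3 (0.26 log units; that floor lies within the scatter). Compound 4 `O=C(Nc1ccc(Cl)c(-c2nnc3c(Cl)cccn23)c1)c1ccc(Cl)cc1` differs from compound 2 in that (4-chlorophenyl in place of 2-methyl-1,3-thiazol-4-yl on a carbonyl carbon). Compound 3, at 54800 nM, carries the closely related 3-chlorophenyl group. Compound 4 is therefore expected to show the step of an at least 2.0-fold lower number from compound 2 to compound 4 (0.30 log units; that floor lies within the scatter) in this assay. The estimate for compound 4 in this assay is 50000 nM, with a range from 20000 nM to 150000 nM.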

Compound 4, half-maximal inhibitory concentration: > 100000 nM
Compound 4 was reported as a limit (the forecaster's own chance of this, stated with the estimate: 30%); middle value at least 2.0-fold (0.30 log units) away from the limit.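

In this assay compound 4 reaches only a limit of the assay, > 100000 nM. Placing 4-chlorophenyl in place of 3-chlorophenyl on the carbonyl carbon gives an at least 1.8-fold higher number from compound 3 to compound 4 (0.26 log units; that floor lies within the scatter), so a chlorophenyl group at this place does not by itself give a readable value. The step between compound 2 and compound 4 cannot be read, as both are limits: the limit of > 100000 nM in this assay, at which 2 of the 4 values shown sit.

As far as these compounds go, it remains open how far compound 4 lies from compound 3. From the compounds shown here alone, it also remains open whether an amine or a carboxylic acid in place of the chlorine on the phenyl ring would give a readable value.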